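Replacing 4-acetylphenyl with 3,4-dimethylphenyl on an amide-type nitrogen

The compounds below may be only part of what the source reports. "The series", "measured", "known", "first", "only" and "open" are said of these compounds alone.

Measured in a functional assay on L1210 cells (Mus musculus) for cytotoxicity; a lower number here means a stronger inhibitor, a higher number a weaker inhibitor:
Compound 1 `O=C(/C=C/C(=O)N1C/C(=C\c2ccccc2)C(=O)/C(=C/c2ccccc2)C1)Nc1ccc(Cl)c(Cl)c1`: 7500 nM
Compound 2 `Cc1cccc(C)c1NC(=O)/C=C/C(=O)N1C/C(=C\c2ccccc2)C(=O)/C(=C/c2ccccc2)C1`: 22000 nM
Compound 3 `CC(=O)c1ccc(NC(=O)/C=C/C(=O)N2C/C(=C\c3ccccc3)C(=O)/C(=C/c3ccccc3)C2)cc1`: 5500 nM

Compound 3 stands level with compound 1, with a 1.4-fold lower number from compound 1 to compound 3 (0.13 log units; within the scatter). It is set apart from compound 2, with a 4.0-fold lower number from compound 2 to compound 3 (0.60 log units; beyond the scatter). The next compound, compound 4 `Cc1ccc(NC(=O)/C=C/C(=O)N2C/C(=C\c3ccccc3)C(=O)/C(=C/c3ccccc3)C2)cc1C`, differs from compound 3 in one place: 3,4-dimethylphenyl in place of 4-acetylphenyl on an amide-type nitrogen. In words, this is 3,4-dimethylphenyl in place of 4-acetylphenyl on an amide-type nitrogen.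

All three measured steps exchange the group at this same place, so all three bear on the change. Among the compounds with values here, the only steps beyond the scatter lead to or from compound 2, with a 2.9-fold higher number from compound 1 to compound 2 (0.47 log units; beyond the scatter), and they are modest. Compound 1 carries the 3,4-dichlorophenyl group, the closest by name to the entering group, and it gives 7500 nM. In this assay, no step beyond the scatter is therefore expected, only a slight drift upward. The expected step is a 1.5-fold higher number from compound 3 to compound 4 (0.16 log units; within the scatter). For compound 4 the estimated value is 8000 nM, with an expected range of 4000 nM to 17000 nM.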

Compound 4, half-maximal inhibitory concentration: 31000 nM
Beside the measured number, compound 4's estimate is 3.9-fold (0.59 log units) below it; measured number above the stated range.
By their numbers in this assay, from the lowest: compounds 3 and 1 (each within the scatter of the next); then compounds 2 and 4 (each within the scatter of the next).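

In this assay the exchange gives a 5.6-fold higher number from compound 3 to compound 4 (0.75 log units; beyond the scatter) and so does not leave the number in place, and the step that puts methyl groups where the 3,4-dichlorophenyl group has chlorines also counts, at a 4.1-fold higher number from compound 1 to compound 4 (0.62 log units; beyond the scatter) on this amide-type nitrogen. Compound 2 no longer stands alone: with a 1.4-fold higher number from compound 2 to compound 4 (0.15 log units; within the scatter) as the step between them, the 2,6-dimethylphenyl and 3,4-dimethylphenyl compounds sit together, apart from compounds 1 and 3. Among these four compounds, then, the two dimethylphenyl groups give the higher numbers whichever way their methyl groups are arranged. Nothing measured here explains this split. On these data alone, whether unsubstituted phenyl or 4-methoxyphenyl would fall with compounds 1 and 3 or with compounds 2 and 4 stays open. So does the effect of an amine or a carboxylic acid on this ring.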